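Swapping Benzyl for Allyl in a Low-Toxicity Series

A few compounds are considered here, and "the series" means these few. Any claim that something is new, unique, unknown or untested is made for them only; others in the source may bear on it.

Compound 1 `O=C(CN1C(=O)CSC1=O)NOCc1ccccc1` carries a benzyloxy group on its amide. In an ADME assay on RAW264.7 cells (Mus musculus) for cytotoxicity, read by neutral red uptake, with a stated time of 24 h (on this read-out higher numbers stand for lower toxicity in this test and lower numbers for higher toxicity in this test), compound 1 gives > 128000 nM, which is a limit of the assay rather than a number. Compound 2 `C=CCONC(=O)CN1C(=O)CSC1=O` differs from it by vinyl in place of phenyl on a saturated chain carbon bound to an oxygen. In this assay compound 2 gives > 128000 nM, again a limit rather than a number. The step between them is a step that the two limits leave unreadable from compound 1 to compound 2, so the two limits leave open whether this change alters toxicity at all.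

Compound 3 `O=C(CN1C(=O)S/C(=C\c2ccc(C(F)(F)F)cc2)C1=O)NOCc1ccccc1` keeps the benzyloxy group but sits on a different core; the difference between the two cores is not broken down here. In this assay compound 3 gives > 128000 nM, once more a limit and not a number. Going by the values given here, every measured value so far rests at the limit of > 128000 nM in this assay, at which 3 of the 3 values shown sit.

Compound 4 `C=CCONC(=O)CN1C(=O)S/C(=C\c2ccc(C(F)(F)F)cc2)C1=O` has not yet been measured. It differs from compound 3 by vinyl in place of phenyl on a saturated chain carbon bound to an oxygen, the same change that turns compound 1 into compound 2, made at the same place. The step from compound 3 to compound 4 is expected to be a step that the limit leaves unreadable from compound 3 to compound 4, because compound 1 and compound 2 both sit at the limit of > 128000 nM in this assay, at which 3 of the 3 values shown sit, and the change between them produced no readable step. Compound 4 is therefore expected to give 200000 nM in this assay, with a range from 100000 nM to 400000 nM, most likely reported again as a limit.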

Compound 4, half-maximal cytotoxic concentration: > 128000 nM
Compound 4: a limit, no number; the forecaster's own chance of this, stated with the estimate: 85%; the middle value does not contradict the limit.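

In this assay compound 4 gives > 128000 nM as a limit and not a number. Going by these compounds alone, no step from compound 3 to compound 4 can be read, so the swap from benzyl to allyl cannot be given a size here: the limit of > 128000 nM in this assay, at which 4 of the 4 values shown sit. The compounds shown leave open whether benzyl and allyl differ in toxicity at all, on either core.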